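The source may hold more compounds than are shown below. What is called first, only, known or untested is meant among the compounds shown, and "the series" means these compounds.

Notes on the series. In a physicochemical assay for metabolic stability, at 50 degrees C, tested at 5 uM (on this read-out higher numbers stand for a longer-lived compound and lower numbers for a shorter-lived compound), compound 1 `Nc1ncnc2c1ncn2[C@@H]1O[C@@H]2CO[P@@](=O)(OCc3ccccc3)O[C@H]2[C@H]1O` gives 0.5 h. In this assay, for the measured compounds named here, compound 2 `Cc1ccc(CO[P@@]2(=O)OC[C@H]3O[C@@H](n4cnc5c(N)ncnc54)[C@H](O)[C@@H]3O2)cc1` gives 0.1 h, the lowest of the two numbers so far; the gap to compound 1 lies beyond the scatter. Compound 3 `Nc1ncnc2c1ncn2[C@@H]1O[C@@H]2CO[P@](=O)(OCc3ccc([N+](=O)[O-])cc3)O[C@H]2[C@H]1O` remains to be measured in this assay. Its structure differs from compound 2 in one place: nitro in place of methyl on an aromatic carbon. Going by the values given here, no measured pair shows this change, so no step size is known from data. A small step, not beyond the scatter, is expected: a 1.5-fold higher number from compound 2 to compound 3 (0.18 log units; within the scatter). Compound 3 is estimated at 0.15 h, with a range from 0.04 h to 0.6 h.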

Compound 3, half-life: 240 h
Estimate against measurement, compound 3: 1600-fold (3.20 log units) below, outside the stated range (above it).
By their numbers in this assay, from the lowest: compound 2; then compound 1; then compound 3.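

In this assay, the aromatic carbon para to a large group proves highly sensitive to what it carries: nitro in place of methyl gives a 2400-fold higher number from compound 2 to compound 3 (3.38 log units; beyond the scatter) on a single substitution. The earlier compounds shown here held only hydrogen or methyl there, so they gave no sign of a change of this size. Nothing available accounts for the size of this step. Still open, going by these compounds, is whether an amine, a methoxy group or a chlorine on this carbon would read closer to compound 2 or to compound 3. Also open, on these data alone, is how nitro would behave on another carbon of the same ring.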